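Replacing an Aromatic Ring with a Saturated One on a Shared Core

The source may hold more compounds than are shown below. What is called first, only, known or untested is meant among the compounds shown, and "the series" means these compounds.

This study follows inhibitors of a methyltransferase, all judged in an assay for inhibition of histone-lysine N-methyltransferase EZH2 variant Y641N (Homo sapiens), read by scintillation counting, with a stated time of 60 min, in the presence of a further agent that is not named here; a higher number here means a weaker inhibitor, a lower number a stronger inhibitor. Compound 1, `COC(c1cc(Cl)c2c(c1Cl)C(=O)N(Cc1c(C)cc(C)[nH]c1=O)CC2)C1CCOCC1`, has been measured more than once, and the record is awkward: the several entries of compound 1 in this assay, 310 nM; 0.1 nM (2 entries). Its entries, 310 nM; 0.1 nM (2 entries), lie far apart, so compound 1 offers no single trustworthy number. Compound 2, `Cc1cc(C)c(CN2CCc3c(Cl)cc(-c4c(C)noc4C)c(Cl)c3C2=O)c(=O)[nH]1`, gives 1.15 nM in this assay; that is the only number shown for it, alongside one entry without a single value, and it is the sole firm anchor for the step that follows.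

Compound 3, `Cc1cc(C)c(CN2CCc3c(Cl)cc([C@@H](CO)[C@H]4CCCO4)c(Cl)c3C2=O)c(=O)[nH]1`, is not yet measured. It differs from compound 2 at a single position: a group of 8 heavy atoms (6 carbon, 2 oxygen; one five-membered non-aromatic ring with 1 hetero atom) in place of a group of 7 heavy atoms (5 carbon, 1 nitrogen, 1 oxygen; one five-membered aromatic ring with 2 hetero atoms), on an aromatic carbon. The shared core and both chloro groups stay in place.

Among the compounds with values here, no measured pair shows what such a swap does, and compound 1, the only neighbour with a saturated oxygen-containing side group, gives conflicting entries. The step from compound 2 to compound 3 is therefore expected to be modest, a 2.6-fold higher number from compound 2 to compound 3 (0.42 log units; beyond the scatter), a slight weakening that may not rise above the scatter. Compound 3 is estimated at 3 nM, with a likely range from 0.5 nM to 20 nM.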

Compound 3, inhibition constant: 110 nM
The estimate for compound 3 lay 37-fold (1.56 log units) below the measured number; the measured number lies above the stated range.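

In this assay, the aromatic carbon ortho to a chloro group proves far from indifferent to what it carries: a 96-fold higher number from compound 2 to compound 3 (1.98 log units; beyond the scatter). Compound 2 and compound 3 both hold a five-membered ring at this place and neither group has a net charge, so those shared features are not enough on their own to keep the number low in this pair. The change alters several things at once, since a non-aromatic ring replaces the aromatic 3,5-dimethyl-1,2-oxazol-4-yl group, a hydrogen-bond donor appears and two defined stereocentres enter, and nothing measured here says which of these accounts for the large step.

As far as these compounds go, one pair cannot separate these features, and compound 1, which also carries a saturated oxygen-containing group at this place, gives no clear second example: the several entries of compound 1 in this assay, 310 nM; 0.1 nM (2 entries) Also open is how a simple phenyl ring, an amine or a carboxylic acid at this aromatic carbon would compare with the 3,5-dimethyl-1,2-oxazol-4-yl group of compound 2 and the saturated group of compound 3.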